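Trimethoxyphenyl Pyrazole Chalcones: Removing One Methoxy Group

A few compounds are considered here, and "the series" means these few. Any claim that something is new, unique, unknown or untested is made for them only; others in the source may bear on it.

Compound 1 `COc1cc(-c2cc(/C=C/C(=O)c3ccc(N)cc3)[nH]n2)cc(OC)c1OC` in a functional assay on NCI-H322M cells (Homo sapiens) for cytotoxicity, read by sulforhodamine B assay, with a stated time of 48 h, tested at 0.01 uM; a higher number here means a weaker effect of the compound at the concentration tested, a lower number a stronger effect: 95%
Compound 2 `COc1ccc(C(=O)/C=C/c2cc(-c3cc(OC)c(OC)c(OC)c3)n[nH]2)cc1OC`: 94%
Compound 3 `COc1ccc(C(=O)/C=C/c2cc(-c3cc(OC)c(OC)c(OC)c3)n[nH]2)cc1`: 92%

The three compounds share a core and differ in the aryl group on the carbonyl carbon. Compound 2 differs from compound 1 by 4-aminophenyl in place of 3,4-dimethoxyphenyl on a carbonyl carbon, a step of a number 1 percentage points lower from compound 1 to compound 2 (within the scatter). From compound 2 to compound 3 the change is hydrogen in place of methoxy on an aromatic carbon, which gave a number 2 percentage points lower from compound 2 to compound 3 (within the scatter). Compound 4 `COc1ccc(-c2cc(/C=C/C(=O)c3ccc(N)cc3)[nH]n2)cc1OC` is not yet measured and arises from compound 1 by hydrogen in place of methoxy on an aromatic carbon. This is the same kind of change as that from compound 2 to compound 3, though not the same: the place in compound 4 is additionally meta to a methoxy group. Because a number 2 percentage points lower from compound 2 to compound 3 (within the scatter) stayed within the scatter, compound 4 is expected to give a number 1 percentage points lower from compound 1 to compound 4 (within the scatter). In this assay compound 4 is estimated at 94%, between 86% and 99%.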

Compound 4, a percentage reported as activity, at one concentration (the size of the read-out at that concentration, not a potency): 96%
Estimate against measurement, compound 4: 2 percentage points below; the range from low to high includes it.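

Hydrogen in place of methoxy on the core of compound 1 gave a number 1 percentage points higher from compound 1 to compound 4 (within the scatter) in this assay. Set beside the same change on the core of compound 2, the step shows no difference that can be read between the two cores: the same change on two cores in this assay, a number 2 percentage points lower (within the scatter) from compound 2 to compound 3 and a number 1 percentage points higher (within the scatter) from compound 1 to compound 4, 3 percentage points apart, within the scatter of two such steps. This shows that the change left no readable mark on either core at this single concentration, but it does not show that the two steps are truly equal, nor that the change would stay this small at a concentration where the compounds have a stronger effect.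

The compounds shown leave open what an ethoxy group, a hydroxy group or a fluorine atom would do at this place on the ring. They also leave open how a carboxylic acid would behave in place of the amino group of compound 1 and compound 4.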